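Pyrimidinyl in Place of Pyridazinyl on a Ketone Core

The compounds below may be only part of what the source reports. "The series", "measured", "known", "first", "only" and "open" are said of these compounds alone.

Measured so far:
compound 1 `CCCCCCCC/C=C\CCCCCCC(=O)c1cccnn1` — 130 nM
compound 2 `O=C(CCCCSCc1ccccc1)c1ncc(-c2ccccn2)o1` — 25 nM
compound 3 `CCCCCCCC/C=C\CCCCCCC(=O)c1ncc(-c2ccoc2)o1` — 610 nM

The three measured compounds were tested in an assay on isolated protein for inhibition of Fatty-acid amide hydrolase 1 (Homo sapiens); a higher number here means a weaker inhibitor, a lower number a stronger inhibitor. Among them, compound 1 stands second highest of the three numbers: compound 3 gives a higher number, and compound 2 a lower number, both gaps beyond the usual scatter. Compound 2 and compound 3 differ from compound 1 in both chain and heteroaryl group, so no single-change comparison exists between any two measured compounds.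

Compound 4 `CCCCCCCC/C=C\CCCCCCC(=O)c1ccncn1` has not yet been measured. It keeps the same atoms as compound 1, joined differently: pyrimidin-4-yl in place of pyridazin-3-yl on a carbonyl carbon. The two six-membered aromatic rings carry the same count of hetero atoms and hydrogen-bond acceptors, so the change is a rearrangement rather than an addition or loss.

With no measured step of this kind on record, one can only reason that such a swap is expected to move the number little, perhaps a modest drop, and the estimated step from compound 1 to compound 4 is a 1.3-fold lower number from compound 1 to compound 4 (0.11 log units; within the scatter). Compound 4 is therefore estimated at 100 nM, with a likely range from 30 nM to 400 nM.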

Compound 4, inhibition constant: 110 nM
Compound 4: the middle estimate sits 1.1-fold (0.04 log units) below what was measured; the measured number falls inside the stated range.
By their numbers in this assay, from the lowest: compound 2; then compounds 4 and 1 (each within the scatter of the next); then compound 3.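

In this assay, within the data shown here, the swap of pyridazin-3-yl for pyrimidin-4-yl on a carbonyl carbon gives the first single-change comparison in this set, and the step of a 1.2-fold lower number from compound 1 to compound 4 (0.07 log units; within the scatter) shows that the two rings cannot be told apart by this read-out. On the chain shared by compound 1 and compound 4, therefore, rearranging the same ring atoms leaves the inhibition constant within the usual scatter, which compound 2 and compound 3 could not show because each differs from compound 1 in more than one place. No available measurement bears on why the two rings read alike.

The compounds shown leave open whether a phenyl or pyrazin-2-yl group on the same carbonyl carbon would also read alike, or whether a ring change at this place can shift the number beyond the scatter at all. They also leave open whether the same swap would read the same on the chain of compound 2, or with a methyl or methoxy group added to either ring.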